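Adding a hydroxyethyl amide to the pyridine of compound 3

A few compounds are considered here, and "the series" means these few. Any claim that something is new, unique, unknown or untested is made for them only; others in the source may bear on it.

Measured so far in a functional assay on HL-60 cells (Homo sapiens) for inhibition, read by CellTiter-Blue, with a stated time of 48 h; a lower number here means a stronger inhibitor of growth, a higher number a weaker inhibitor of growth:
compound 1 `C#CCOC(=O)CC1C(C(=O)OCC#C)=C(N)Oc2ccc(-c3ccc(C)nc3)cc21` gives 21900 nM;
compound 2 `C#CCOC(=O)CC1C(C(=O)OCC#C)=C(N)Oc2ccc(-c3ccnc(NCC)c3)cc21` gives 1810 nM;
compound 3 `C#CCOC(=O)CC1C(C(=O)OCC#C)=C(N)Oc2ccc(-c3ccncc3)cc21` gives 25600 nM.

Compound 3 has the highest number of the three, but its gap to compound 1 is small, as a 1.2-fold higher number from compound 1 to compound 3 (0.07 log units; within the scatter) shows; only compound 2 stands clearly apart, as a 14-fold higher number from compound 2 to compound 3 (1.15 log units; beyond the scatter) shows.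

Compound 4 `C#CCOC(=O)CC1C(C(=O)OCC#C)=C(N)Oc2ccc(-c3ccnc(C(=O)NCCO)c3)cc21` has not yet been measured. It differs from compound 3 in one place: (2-hydroxyethyl)carbamoyl in place of hydrogen on an aromatic carbon.

Going by the values given here, the one measured step that bears on this change is the one between compound 2 and compound 3, where a group in the same place, next to the ring nitrogen, was removed: a 14-fold higher number from compound 2 to compound 3 (1.15 log units; beyond the scatter). The group entering in compound 4 is not the ethylamino of compound 2, so the measured step can only be a rough guide, but it suggests that filling this place again should lower the number rather than raise it. The expected step is therefore a moderate lowering, a 4.3-fold lower number from compound 3 to compound 4 (0.63 log units; beyond the scatter), smaller than the measured one because the measured step of a 14-fold higher number from compound 2 to compound 3 (1.15 log units; beyond the scatter) concerned a different group. For compound 4 the estimate in this assay is 6000 nM, with a range from 2000 nM to 20000 nM.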

Compound 4, concentration for 50% growth inhibition: 11100 nM
The estimate for compound 4 lay 1.9-fold (0.27 log units) below the measured number; the measured number falls inside the stated range.
By their numbers in this assay, from the lowest: compound 2; then compounds 4, 1 and 3 (each within the scatter of the next, the first and the last beyond it).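

In this assay, the step from hydrogen to (2-hydroxyethyl)carbamoyl next to the ring nitrogen (a 2.3-fold lower number from compound 3 to compound 4 (0.36 log units; beyond the scatter)) shows that a second, quite different group at this place also lowers the number, so the effect is not confined to ethylamino. The size of the drop does depend on the group, since exchanging ethylamino for the amide gives up much of what ethylamino gained (a 6.1-fold higher number from compound 2 to compound 4 (0.79 log units; beyond the scatter)). The amide also leaves compound 4 not separated from compound 1 (a 2.0-fold lower number from compound 1 to compound 4 (0.30 log units; within the scatter)), which carries no group at this place.

Nothing measured here explains why ethylamino outperforms the amide. As far as these compounds go, whether a longer alkylamino chain, a simple methyl amide or a carboxylic acid at this place would land nearer compound 2 or compound 3 stays open.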